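This account rests on a few compounds, and the source may have more. Where it says the series, first, only, none or still open, it means among the compounds named here.

Compound 3 `COc1cc(Cl)cc(-c2nn(-c3cccc(NC(=O)Nc4cccc(C(F)(F)F)c4)c3)cc2-c2ccncc2)c1` belongs to a small set of three compounds that share one core and differ only in the group attached to the carbonyl carbon of a side chain. In a functional assay on U-251 cells (Homo sapiens) for inhibition, read by sulforhodamine B assay, with a stated time of 48 h, tested at 10 uM (on this read-out lower numbers stand for a stronger effect and higher numbers for a weaker effect at the one concentration tested), compound 3 gives 4.59%. Compound 2 `COc1cc(Cl)cc(-c2nn(-c3cccc(NC(=O)Nc4ccc(Cl)c(Cl)c4)c3)cc2-c2ccncc2)c1` gives 3.01%, and the two sit close: a number 1.6 percentage points higher from compound 2 to compound 3 (within the scatter). Compound 1 `COc1cc(Cl)cc(-c2nn(-c3cccc(NC(=O)c4ccc(Cl)c(Cl)c4)c3)cc2-c2ccncc2)c1` gives 64.1%, so compound 3 stands second highest of the three, near compound 2 and far from compound 1.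

Compound 4 `COc1cc(Cl)cc(-c2nn(-c3cccc(NC(=O)c4cccc(C(F)(F)F)c4)c3)cc2-c2ccncc2)c1` has not yet been measured in this assay. The change from compound 3 is 3-(trifluoromethyl)phenyl in place of (3-(trifluoromethyl)phenyl)amino on a carbonyl carbon.

Among the compounds with values here, two measured steps bear on this change, both going the opposite way, from an aryl group to an arylamino group on the carbonyl carbon: a number 61.1 percentage points lower from compound 1 to compound 2 (beyond the scatter) and a number 59.5 percentage points lower from compound 1 to compound 3 (beyond the scatter). Reversing such a change should therefore raise the number by a large amount, meaning a weaker effect. Compound 4 is expected to give roughly 60%, with a range from 35% to 85%, which corresponds to an expected step of a number 55.4 percentage points higher from compound 3 to compound 4 (beyond the scatter).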

Compound 4, a percentage reported as activity, at one concentration (the size of the read-out at that concentration, not a potency): 49.2%
Estimate against measurement, compound 4: 10.8 percentage points above; the measured number falls inside the stated range.
By their numbers in this assay, from the lowest: compounds 2 and 3 (each within the scatter of the next); then compound 4; then compound 1.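

With the 3-(trifluoromethyl)phenyl group kept, replacing (3-(trifluoromethyl)phenyl)amino with 3-(trifluoromethyl)phenyl on the carbonyl carbon in this assay gives a number 44.6 percentage points higher from compound 3 to compound 4 (beyond the scatter) and so weakens the effect sharply. The comparison with the dichlorinated arylamino compound points the same way, with a number 46.2 percentage points higher from compound 2 to compound 4 (beyond the scatter) as another large step, so the loss is not confined to one aryl group. The aryl group itself also counts once the amino link is absent, as a number 14.9 percentage points lower from compound 1 to compound 4 (beyond the scatter) is a modest step beyond the scatter, whereas a number 1.6 percentage points higher from compound 2 to compound 3 (within the scatter) stays within it among the arylamino compounds.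

Still open, as far as these compounds go, is whether an oxygen atom or a methylene group in place of the amino nitrogen would keep the low numbers of compound 2 and compound 3. Nothing measured here explains the size of these steps.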